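The compounds below may be only part of what the source reports. "The series", "measured", "known", "first", "only" and "open" are said of these compounds alone.

Of the compounds shown here, three that share a dichlorinated core have been measured in a functional assay on HCT-116 cells (Homo sapiens) for cytotoxicity, read by MTT assay, with a stated time of 48 h; a higher number here means a weaker inhibitor of growth, a lower number a stronger inhibitor of growth. Compound 1 (`Cn1c(C(F)(F)F)nc2cc(Cl)c(Cl)cc21`) gives 56000 nM, compound 2 (`O=[N+]([O-])c1ccc(Cn2c(C(F)(F)F)nc3cc(Cl)c(Cl)cc32)cc1`) gives 81600 nM, and compound 3 (`Clc1cc2ncn(C3CCCC3)c2cc1Cl`) gives 37000 nM. Compound 3 stands within the scatter of compound 1, while its number is lower than that of compound 2 by a gap just beyond the scatter.

The next compound, compound 4 (`CSc1nc2cc(Cl)c(Cl)cc2n1C1CCCC1`), takes compound 3 as its starting point. The change is methylsulfanyl in place of hydrogen on an aromatic carbon, between two ring nitrogen atoms and next to the ring atom that bears a cyclopentyl group.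

Within the data shown here, no two measured compounds differ in one place only, so the data show no direct precedent for this change. Among the measured compounds shown here, the only guide is the narrow spread of the measured values, with compound 3 at 37000 nM and compound 2 at 81600 nM. On that basis, no step beyond the scatter is expected in this assay. The expected change is a 1.2-fold lower number from compound 3 to compound 4 (0.09 log units; within the scatter), and this estimate carries wide uncertainty in either direction. For compound 4 the estimated value is 30000 nM, with an expected range of 12000 nM to 75000 nM.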

Compound 4, concentration for 50% growth inhibition: 2900 nM
Beside the measured number, compound 4's estimate is 10-fold (1.01 log units) above it, and the stated range ends above it.
By their numbers in this assay, from the lowest: compound 4; then compounds 3, 1 and 2 (each within the scatter of the next, the first and the last beyond it).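

In this assay the change from hydrogen to methylsulfanyl gives a 13-fold lower number from compound 3 to compound 4 (1.11 log units; beyond the scatter) and so shows that this aromatic carbon, between two ring nitrogen atoms, is not indifferent to substitution. The earlier compounds shown here offered no pair differing in one place and could therefore say nothing about this position, whereas here a group of only 2 heavy atoms moves the number well beyond the scatter with the cyclopentyl group and the rest of the structure held constant. Nothing measured for these compounds accounts for the size of this step.

On these data alone, with only hydrogen and methylsulfanyl compared directly at this carbon, it remains open whether the sulfur atom matters or whether another small substituent would do the same, and a methoxy group, an amine or a longer thioether such as ethylsulfanyl at the same place would separate these readings. As far as these compounds go, it also remains open whether the step depends on the cyclopentyl group, which a methyl or a benzyl group in its place, with methylsulfanyl kept, would test.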